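The source may hold more compounds than are shown below. What is called first, only, known or untested is meant among the compounds shown, and "the series" means these compounds.

Measured compounds:
- compound 1, `Fc1ccc(-c2nn3c(NC4CCCC4)cccc3c2-c2ccncc2)cc1`, gives 20000 nM
- compound 2, `Cc1nc(-c2c(-c3ccc(F)cc3)nn3c(NC4CCCC4)cccc23)co1`, gives "not determined" (no result reported)
- compound 3, `Nc1nc(-c2c(-c3ccc(F)cc3)nn3c(NC4CCCC4)cccc23)cs1`, gives "not determined" (no result reported)

For the measured compounds named here, in an ADME assay on Vero cells (Chlorocebus sabaeus) for cytotoxicity (on this read-out higher numbers stand for lower toxicity in this test and lower numbers for higher toxicity in this test), compound 1 is the only compound of the three with a number: a high value, which on this read-out means low toxicity in this test. Compound 2 and compound 3 were both taken into the same test, but for neither is a result reported, so compound 3 stands without a number, and the further entry without a number is compound 2. The shared core of all three compounds carries a cyclopentylamino group and a 4-fluorophenyl group, and they differ only in the ring attached on an aromatic carbon of the core.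

Compound 4, `Fc1ccc(-c2nn3c(NC4CCCC4)cccc3c2-c2cn[nH]c2)cc1`, continues this series with a change from compound 3: 1H-pyrazol-4-yl in place of 2-amino-1,3-thiazol-4-yl on an aromatic carbon. Going by the values given here, no measured pair in this set tells how such a change moves the numbers, and compound 3 itself has no value to move from. Among the compounds with values here, the only anchor is compound 1, which with a different ring on the same carbon shows low toxicity in this test. Compound 4 is therefore expected to land in the same region, with the estimate 20000 nM and a range from 8000 nM to 50000 nM, and a fair chance that only a limit is reported.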

Compound 4, half-maximal cytotoxic concentration: 10000 nM
For compound 4 the middle estimate is 2.0-fold (0.30 log units) above the measured one, within the range that was stated.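

In this assay, the pyrazole result gives this position a second ring with a number: putting 1H-pyrazol-4-yl in place of pyridin-4-yl on an aromatic carbon of the five-membered aromatic ring with 2 nitrogen gives a 2.0-fold lower number from compound 1 to compound 4 (0.30 log units; within the scatter), so the two compounds cannot be told apart on this read-out. Compound 1 alone could not show this, whereas the pair shows that, for these two rings, exchanging one for the other leaves the read-out within the usual scatter of repeated measurements and that both compounds share the same low-toxicity region of the test. Nothing shown gives a reason for this result, and the steps from compound 2 and compound 3 cannot be read.

Two rings are a narrow sample, so the compounds shown leave open whether the same holds for a group of another kind on this carbon, such as a carboxylic acid, a primary amine or a longer chain. They also leave open how the read-out responds when the cyclopentylamino group or the 4-fluorophenyl group is exchanged, since both stay the same in every compound here.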